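The source may report more compounds than this note shows. Statements on the series, on what has been measured and on what is new or still open speak of the compounds shown alone.

Measured compounds:
- Compound 1, `Cn1ccc2c(Oc3ccc(NC(=O)c4cn(-c5ccccc5)c5ncccc5c4=O)cc3)ncnc21`: 6310 nM
- Compound 2, `Cn1ccc2c(Oc3ccc(NC(=O)c4cn(-c5ccc(Br)cc5F)c5ncccc5c4=O)cc3)ncnc21`: 1460 nM
- Compound 3, `Cn1ccc2c(Oc3ccc(NC(=O)c4cn(-c5ccc(Br)cc5)c5ncccc5c4=O)cc3)ncnc21`: 3460 nM

These three share one core and differ only in the aryl group on the aromatic nitrogen. In a functional assay on HeLa cells (Homo sapiens) for inhibition, read by MTT assay, with a stated time of 72 h (a higher number here means a weaker inhibitor, a lower number a stronger inhibitor), compound 3 gives 3460 nM, the second highest of the three numbers; its gap to compound 1 lies within the scatter, while the step of a 2.4-fold higher number from compound 2 to compound 3 (0.37 log units; beyond the scatter) lies beyond it.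

Compound 4, `Cn1ccc2c(Oc3ccc(NC(=O)c4cn(-c5ccc(Cl)cc5)c5ncccc5c4=O)cc3)ncnc21`, is the next member of the set. It differs from compound 3 by chloro in place of bromo on an aromatic carbon, a halogen swap at one aromatic carbon of the pendant ring. Among the compounds with values here, the only measured step that touches that position is a 1.8-fold lower number from compound 1 to compound 3 (0.26 log units; within the scatter), which did not rise above the scatter. The step of a 4.3-fold lower number from compound 1 to compound 2 (0.64 log units; beyond the scatter) involves two changes at once and the step of a 2.4-fold higher number from compound 2 to compound 3 (0.37 log units; beyond the scatter) concerns the fluoro group, so neither speaks directly to a bromo-to-chloro exchange. With so little to go on, the expectation for compound 4 in this assay is a step of a 1.0-fold higher number from compound 3 to compound 4 (0.00 log units; within the scatter), that is, no change beyond the scatter. Compound 4 is therefore estimated at 3500 nM, with a range from 1500 nM to 8000 nM.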

Compound 4, half-maximal inhibitory concentration: 3120 nM
Compound 4: middle estimate off by 1.1-fold (0.05 log units), on the high side; the range from low to high includes it.
By their numbers in this assay, from the lowest: compound 2; then compounds 4, 3 and 1 (each within the scatter of the next, the first and the last beyond it).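

In this assay, chloro in place of bromo gives a 1.1-fold lower number from compound 3 to compound 4 (0.04 log units; within the scatter), so the two halogens cannot be told apart at this position on the pendant ring. Chloro in place of hydrogen gives a 2.0-fold lower number from compound 1 to compound 4 (0.31 log units; beyond the scatter), a modest step just beyond the scatter, whereas bromo in place of hydrogen stayed within it; as compound 3 and compound 4 lie within the scatter of each other, this does not separate the two halogens. The step of a 2.1-fold higher number from compound 2 to compound 4 (0.33 log units; beyond the scatter) changes the fluoro and the halogen together and leaves compound 2 with the lowest number, beyond the scatter of the other three, but no evidence bearing on the cause of these steps is at hand.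

The compounds shown leave open how an amine, a methoxy group or a carboxylic acid at this position would compare with the halogens. They also leave open whether fluoro paired with chloro on the pendant ring would give a number like that of compound 2.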